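This account rests on a few compounds, and the source may have more. Where it says the series, first, only, none or still open, it means among the compounds named here.

Measured in a functional assay on HCT-116 cells (Homo sapiens) for antiproliferative activity, read by MTT assay, with a stated time of 72 h; on this read-out lower numbers stand for stronger inhibition and higher numbers for weaker inhibition:
- Compound 1 `C=CC(=O)Nc1ccc(Cl)c(S(=O)(=O)N(C)C)c1`: 24600 nM
- Compound 2 `C=CC(=O)Nc1nc(-c2ccccc2OC)cs1`: > 30000 nM (a limit, not a number)
- Compound 3 `C=CC(=O)N(Cc1cc(C)no1)c1nc(-c2ccccc2OC)cs1`: > 30000 nM (a limit, not a number)

Compound 3 has no exact value, only a limit of this assay. It stands at the limit of > 30000 nM in this assay, at which 2 of the 3 values shown sit.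

Compound 4 `C=CC(=O)N(Cc1cc(C)no1)c1nc(-c2ccc(Cl)cc2O)cs1` keeps the rest of compound 3 but carries 4-chloro-2-hydroxyphenyl in place of 2-methoxyphenyl on an aromatic carbon. The change is 4-chloro-2-hydroxyphenyl in place of 2-methoxyphenyl on an aromatic carbon.

Going by the values given here, the only measured step involving compound 3 is a step that the two limits leave unreadable from compound 2 to compound 3. That step concerns an amide-type nitrogen, not the aromatic group that changes here. Among the compounds with values here, no measured step covers this swap, and none supplies a size to carry over.

A readable number for compound 4 could only lie on the stronger side of the limit of compound 3. Within the data shown here, the only readable number in the set belongs to compound 1, at 24600 nM, and its different structure makes it a loose guide at best. Compound 4 may also return only a limit.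

The expected change is modest and uncertain: an at least 2.0-fold lower number from compound 3 to compound 4 (0.30 log units; that floor lies within the scatter). Compound 4 is expected at 15000 nM, with an estimated range of 3000 nM to 30000 nM.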

Compound 4, half-maximal inhibitory concentration: > 30000 nM
Compound 4 ended at the assay's limit (the forecaster's own chance of this, stated with the estimate: 45%); middle value at least 2.0-fold (0.30 log units) away from the limit.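

Compound 4, like compound 3, gives only a limit and not a number, and both sit at the same mark: the limit of > 30000 nM in this assay, at which 3 of the 4 values shown sit. Going by these compounds alone, no step between compound 3 and compound 4 can be read. The compounds shown leave open whether 4-chloro-2-hydroxyphenyl in place of 2-methoxyphenyl changes antiproliferative activity at all.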